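The source may hold more compounds than are shown below. What is called first, only, known or untested is meant among the compounds shown, and "the series" means these compounds.

Measured compounds:
Compound 1 `Cc1cc(C(=O)O)nn1C(C)c1cc(Cl)ccc1OCc1ccccc1` — 10 nM
Compound 2 `Cc1cc(C(=O)Nc2ccc(F)cc2)nn1Cc1cc(Cl)ccc1OCc1ccccc1` — 79.4 nM
Compound 3 `Cc1cc(C(=O)NCc2ccccn2)nn1Cc1cc(Cl)ccc1OCc1ccccc1` — 25.1 nM

In an assay on CHO-K1 cells for displacement of a labelled ligand from prostaglandin E2 receptor EP1 subtype (Homo sapiens) (a higher number here means a weaker inhibitor, a lower number a stronger inhibitor), compound 2 gives the highest number of the three. Its nearest neighbour is compound 3, at a 3.2-fold lower number from compound 2 to compound 3 (0.50 log units; beyond the scatter), and compound 1 lies furthest from it with the lowest number of the set.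

The unmeasured compound 4 `Cc1cc(NC(=O)C2CCOC2)nn1Cc1cc(Cl)ccc1OCc1ccccc1` differs from compound 2 at the aromatic carbon of the five-membered aromatic ring with 2 nitrogen: ((oxolan-3-yl)carbonyl)amino in place of (4-fluorophenyl)carbamoyl on an aromatic carbon. Going by the values given here, one measured step bears on it. Going from compound 2 to compound 3, replacement of the 4-fluorophenyl on the amide-type nitrogen by a (pyridin-2-yl)methyl gave a 3.2-fold lower number from compound 2 to compound 3 (0.50 log units; beyond the scatter), so a change away from the (4-fluorophenyl)carbamoyl in this region has once lowered the number. Compound 4 changes the same region, though with a different group and a different attachment, so a modest step downward in this assay is expected, with wide uncertainty: a 2.5-fold lower number from compound 2 to compound 4 (0.39 log units; beyond the scatter). Compound 4 is therefore estimated at 32 nM, within a range of 10 nM to 100 nM.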

Compound 4, half-maximal inhibitory concentration: 39.8 nM
Estimate against measurement, compound 4: 1.2-fold (0.09 log units) below; the range from low to high includes it.
By their numbers in this assay, from the lowest: compound 1; then compounds 3, 4 and 2 (each within the scatter of the next, the first and the last beyond it).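

In this assay, the earlier step had changed only the group on the amide-type nitrogen, whereas compound 4 replaces the (4-fluorophenyl)carbamoyl with ((oxolan-3-yl)carbonyl)amino on the same aromatic carbon. The result stays within the scatter of both amide neighbours (a 2.0-fold lower number from compound 2 to compound 4 (0.30 log units; within the scatter); a 1.6-fold higher number from compound 3 to compound 4 (0.20 log units; within the scatter)), so among these three compounds, neither the six-membered aromatic ring of compound 2 nor the carbamoyl attachment shared by compound 2 and compound 3 is required for a number in this range. Nothing measured here explains this outcome.

The compounds shown leave open whether the oxolan-3-yl ring itself matters, since no open-chain acyl group such as butanoyl is compared with it at this position. They also leave open how a simple amine on this aromatic carbon would behave.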